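Nitro for trifluoromethyl on the aryl ring

The source may report more compounds than this note shows. Statements on the series, on what has been measured and on what is new or still open speak of the compounds shown alone.

Compound 1 `C=C(C)C(=O)c1ccc(OCc2nc(-c3ccc(O)cc3)no2)c(C)c1C` gives 3400 nM in an assay on HL-60 cells for inhibition of glutathione S-transferase P (Homo sapiens); a higher number here means a weaker inhibitor, a lower number a stronger inhibitor. For the measured compounds named here, compound 2 `C=C(C)C(=O)c1ccc(OCc2nc(-c3ccc(C(F)(F)F)cc3)no2)c(C)c1C` gives 3900 nM in this assay, the higher of the two numbers measured so far, though the step of a 1.1-fold higher number from compound 1 to compound 2 (0.06 log units; within the scatter) lies within the scatter, so neither compound can be called the weaker. Compound 3 `C=C(C)C(=O)c1ccc(OCc2nc(-c3ccc([N+](=O)[O-])cc3)no2)c(C)c1C` has not yet been measured. The change from compound 2 to compound 3 is nitro in place of trifluoromethyl on an aromatic carbon. Going by the values given here, the only step that bears on this position is a 1.1-fold higher number from compound 1 to compound 2 (0.06 log units; within the scatter), where exchanging one group for another at the same place left the number unchanged within the scatter. Among the compounds with values here, the nitro group itself has no measured counterpart. No shift beyond the scatter is therefore expected in this assay, and the step from compound 2 to compound 3 is estimated as a 1.0-fold lower number from compound 2 to compound 3 (0.01 log units; within the scatter). Compound 3 is expected to give 3800 nM, within 1500 nM to 9500 nM.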

Compound 3, half-maximal inhibitory concentration: 2300 nM
Compound 3: middle estimate off by 1.7-fold (0.22 log units), on the high side; the range from low to high includes it.
By their numbers in this assay, from the lowest: compounds 3, 1 and 2 (each within the scatter of the next).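

In this assay, a third group at this place, on an aromatic carbon para to a large group, gives a 1.7-fold lower number from compound 2 to compound 3 (0.23 log units; within the scatter), and against the hydroxy compound it gives a 1.5-fold lower number from compound 1 to compound 3 (0.17 log units; within the scatter). Hydroxy, trifluoromethyl and nitro now all stand at the same place on the shared core, and none of the steps among compounds 1, 2 and 3 leaves the scatter, so this exchange gives no ranking of the three groups. No data at hand bear on why the numbers of these three compounds stay so close.

Going by these compounds, whether an amine, a carboxylic acid or a longer chain at this place would move the number beyond the scatter remains open. On these data alone, the core is also the same in all three compounds, so what a change elsewhere in it would do is equally open.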